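The source may hold more compounds than are shown below. What is called first, only, known or untested is meant among the compounds shown, and "the series" means these compounds.

Working notes on the series. Compound 1 `CCOC(=O)c1nn(-c2ccc(C(C)(C)C)cc2)c(=O)c2c(N)scc12` gives 9750 nM in an assay on CHO-K1 cells with adenosine receptor A1 (Homo sapiens) as the target; on this read-out lower numbers stand for an effect already at smaller amounts and higher numbers for an effect only at larger amounts of compound. Compound 2 `CCOC(=O)c1nn(-c2ccc(C(F)(F)F)cc2)c(=O)c2c(N)scc12` gives 8400 nM in this assay, and the step of a 1.2-fold lower number from compound 1 to compound 2 (0.06 log units; within the scatter) leaves compound 2 standing alongside compound 1 within the scatter. Compound 3 `CCOC(=O)c1nn(-c2ccc([N+](=O)[O-])cc2)c(=O)c2c(N)scc12` differs from compound 2 by nitro in place of trifluoromethyl on an aromatic carbon. For the measured compounds named here, the one measured step bears on this change, since it also exchanged the group at this place on the ring, and it stayed within the scatter. For compound 3 no shift beyond the scatter is therefore expected, a 1.1-fold lower number from compound 2 to compound 3 (0.02 log units; within the scatter). Compound 3 is estimated at 8000 nM, with a range from 3000 nM to 25000 nM.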

Compound 3, half-maximal effective concentration: 13000 nM
Beside the measured number, compound 3's estimate is 1.6-fold (0.21 log units) below it, and the stated range covers the measured number.
By their numbers in this assay, from the lowest: compounds 2, 1 and 3 (each within the scatter of the next).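

At this place, on an aromatic carbon para to a large group, nitro gives a 1.5-fold higher number from compound 2 to compound 3 (0.19 log units; within the scatter) and a 1.3-fold higher number from compound 1 to compound 3 (0.12 log units; within the scatter) in this assay. Exchanging trifluoromethyl, with 0 hydrogen-bond acceptors, for nitro, with 2, therefore leaves the number within the scatter, as the earlier exchange of tert-butyl for trifluoromethyl did. No available data give a reason for this flat result. Going by these compounds, whether an amine, a carboxylic acid or a longer chain here would move the number beyond the scatter remains open.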